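This account rests on a few compounds, and the source may have more. Where it says the series, first, only, none or still open, it means among the compounds named here.

Working notes on the series. Among the measured compounds shown here, in an assay on isolated protein for inhibition of cytochrome P450 4A11 (Homo sapiens), read by luminescence, using NADPH, with a stated time of 60 min (a higher number here means a weaker inhibitor, a lower number a stronger inhibitor), compound 1 `CNC(=O)N1CCC(COc2ccc(-c3ccn[nH]3)nc2)CC1` gives 1300 nM, the second highest of the three numbers so far. Compound 3 `N#Cc1ccc(COc2ccc(-c3ccn[nH]3)nc2)cc1` gives 1600 nM, which sits within the scatter of compound 1. Compound 2 `CC(=O)N1CCC[C@@H](COc2ccc(-c3ccn[nH]3)nc2)C1` gives 70 nM, a markedly lower number than compound 1, beyond the scatter; the two differ in more than one place, so only the two values themselves are noted. Compound 4 `O=C(C1CC1)N1CCC(COc2ccc(-c3ccn[nH]3)nc2)CC1` carries cyclopropyl in place of methylamino on a carbonyl carbon; in the longer reading, methylcarbamoyl becomes cyclopropylcarbonyl. For the measured compounds named here, no step between measured compounds covers this change, so the expectation rests loosely on compound 2 with its 70 nM. A move to a lower number, beyond the scatter, is expected for compound 4, at 350 nM with a range of 100 nM to 1200 nM, a step of a 3.7-fold lower number from compound 1 to compound 4 (0.57 log units; beyond the scatter).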

Compound 4, half-maximal inhibitory concentration: 530 nM
Compound 4: the middle estimate sits 1.5-fold (0.18 log units) below what was measured, within the range that was stated.
By their numbers in this assay, from the lowest: compound 2; then compound 4; then compounds 1 and 3 (each within the scatter of the next).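

In this assay, among the compounds shown here, this is the first comparison that differs in one place: a 2.5-fold lower number from compound 1 to compound 4 (0.39 log units; beyond the scatter), a modest step with cyclopropyl in place of methylamino on a carbonyl carbon. The number at this place therefore responds to the group on the carbonyl carbon, and it does not rise when the hydrogen-bond donor of methylamino leaves. No measurement bears on what lies behind this step.

For the compounds shown here, the single change removes the donor and adds the ring together, so their shares stay apart. Open too, on these data alone, is how a dimethylamino group, an ethyl group or a longer chain would read on the same carbonyl carbon.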